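The compounds below may be only part of what the source reports. "The series", "measured", "known", "first", "only" and "open" are said of these compounds alone.

Of the compounds shown here, two built on a shared core have been read so far in a physicochemical assay for solubility, in phosphate buffer, with a stated time of 18 h, at pH 7.4; on this read-out higher numbers stand for higher solubility and lower numbers for lower solubility. Compound 1 (`COCCOc1cc2c(-n3nc(-c4ccccn4)nc3N)ncnc2cc1OC`) gives 8000 nM, and compound 2 (`COc1cc2ncnc(-n3nc(-c4ccccn4)nc3N)c2cc1OCCCNC(=O)CN1C[C@@H](C)O[C@@H](C)C1`) gives 34000 nM, which is the higher of the two numbers by a gap beyond the scatter of repeat measurements. The next compound is compound 3 (`COc1cc2ncnc(-n3nc(-c4ccccn4)nc3N)c2cc1OCCCCNC(=O)OC(C)(C)C`), and the change from compound 2 is ((tert-butoxycarbonyl)amino)methyl in place of (((2,6-dimethylmorpholin-4-yl)methyl)carbonyl)amino on a saturated chain carbon, three bonds along the chain from an oxygen on an aromatic ring. In words, ((tert-butoxycarbonyl)amino)methyl stands in place of (((2,6-dimethylmorpholin-4-yl)methyl)carbonyl)amino on a saturated chain carbon, three bonds along the chain from an oxygen on an aromatic ring. Among the compounds with values here, no measured pair differs in one place only, so any guide here is indirect. Compound 1, which also lacks the six-membered non-aromatic ring, reads 8000 nM. A downward move beyond the scatter is therefore expected, with an estimated 11-fold lower number from compound 2 to compound 3 (1.05 log units; beyond the scatter). The estimate for compound 3 is 3000 nM, within an expected range of 600 nM to 12000 nM.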

Compound 3, solubility: 500 nM
Beside the measured number, compound 3's estimate is 6.0-fold (0.78 log units) above it; the whole stated range lies above it.
By their numbers in this assay, from the lowest: compound 3; then compound 1; then compound 2.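

In this assay, putting ((tert-butoxycarbonyl)amino)methyl in place of (((2,6-dimethylmorpholin-4-yl)methyl)carbonyl)amino on a saturated chain carbon, three bonds along the chain from an oxygen on an aromatic ring, gives a 68-fold lower number from compound 2 to compound 3 (1.83 log units; beyond the scatter). Compound 3 also falls well under compound 1, which carries methoxy where compound 3 has 2-((tert-butoxycarbonyl)amino)ethyl, with a 16-fold lower number from compound 1 to compound 3 (1.20 log units; beyond the scatter). The read-out at this position therefore moves strongly with what the chain carries, and compound 3 is the lowest of the three, with both of its steps beyond the scatter.

Still open, on these data alone, is which part of the change matters, as the six-membered ring and the tert-butoxycarbonyl group are exchanged in one step, and how a free primary amine on the same chain would read. No measurement here explains these drops.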